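Aryl variation on the triazole nitrogen: towards compound 4

The source may report more compounds than this note shows. Statements on the series, on what has been measured and on what is new or still open speak of the compounds shown alone.

Among the measured compounds shown here, compound 1 `Cc1cccc(-n2nncc2CN2C(=O)C3(C(C#N)=C(N)Oc4c(N)cc5nc6ccccc6nc5c43)c3ccccc32)c1` is the only member of the series with a number in a functional assay on A549 cells (Homo sapiens) for antiproliferative activity, read by MTT assay, with a stated time of 48 h (a higher number here means a weaker inhibitor, a lower number a stronger inhibitor), where compound 1 gives 12300 nM. Compound 2 `N#CC1=C(N)Oc2c(N)cc3nc4ccccc4nc3c2C12C(=O)N(Cc1cnnn1-c1ccc(F)cc1)c1ccccc12` reaches only the limit of this assay, > 50000 nM. Compound 3 `Cc1ccc(-n2nncc2CN2C(=O)C3(C(C#N)=C(N)Oc4c(N)cc5nc6ccccc6nc5c43)c3ccccc32)cc1C` likewise stands at the limit of this assay, > 50000 nM. Compound 3 therefore sits at the weak end of the shown range, as the limit of > 50000 nM in this assay, at which 2 of the 3 values shown sit, holds two of the three values. Compound 4 `Cc1ccc(Cl)cc1-n1nncc1CN1C(=O)C2(C(C#N)=C(N)Oc3c(N)cc4nc5ccccc5nc4c32)c2ccccc21` differs from compound 3 by 5-chloro-2-methylphenyl in place of 3,4-dimethylphenyl on an aromatic nitrogen. For the measured compounds named here, no direct step joins compound 3 and compound 4; the steps of an at least 4.0-fold higher number from compound 1 to compound 2 (0.60 log units; beyond the scatter) and an at least 4.0-fold higher number from compound 1 to compound 3 (0.60 log units; beyond the scatter) show that either exchange of the aryl group on the aromatic nitrogen costs at least modest activity, while a step that the two limits leave unreadable from compound 2 to compound 3 remains unreadable. Compound 4 is therefore expected to give a step of an at least 1.6-fold lower number from compound 3 to compound 4 (0.22 log units; that floor lies within the scatter), landing at an estimated 30000 nM with a range from 8000 nM to 100000 nM, and a fair chance of returning only a limit.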

Compound 4, half-maximal inhibitory concentration: > 50000 nM
Compound 4: a limit, no number; the forecaster's own chance of this, stated with the estimate: 45%; middle value at least 1.6-fold (0.22 log units) from the limit.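

In this assay compound 4 also returns only a limit, so a chlorine-bearing aryl group with a methyl on it fares no better on this nitrogen than the 4-fluorophenyl and 3,4-dimethylphenyl groups. The exchange of 3-methylphenyl for 5-chloro-2-methylphenyl gives an at least 4.0-fold higher number from compound 1 to compound 4 (0.60 log units; beyond the scatter), a third such exchange with a cost, while the steps among compound 2, compound 3 and compound 4 cannot be read. Compound 1 remains the only one with a number, and the limit now holds most of the set: the limit of > 50000 nM in this assay, at which 3 of the 4 values shown sit.

Open, going by these compounds, is whether a 3-chlorophenyl or 3-methoxyphenyl group would keep a number in this assay. Also open, on these data alone, is whether an aryl group carrying an amine or a carboxylic acid would do so.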